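This account rests on a few compounds, and the source may have more. Where it says the series, first, only, none or still open, it means among the compounds named here.

Measured in a functional assay on A2780 cells (Homo sapiens) for antiproliferative activity, read by fluorescence, with a stated time of 72 h; on this read-out lower numbers stand for stronger inhibition and higher numbers for weaker inhibition:

- Compound 1 `CN1CCC(C(=O)N2Cc3c(NC(=O)C4CC4)n[nH]c3C2(C)C)CC1`: 1420 nM
- Compound 2 `CN1CCC(C(=O)N2Cc3c(NC(=O)c4cc(F)cc(F)c4)n[nH]c3C2(C)C)CC1`: 130 nM
- Compound 3 `CN1CCC(C(=O)N2Cc3c(NC(=O)c4ccc(F)c(F)c4)n[nH]c3C2(C)C)CC1`: 100 nM

Compound 3 sits at the low end of this small set. Its nearest step is a 1.3-fold lower number from compound 2 to compound 3 (0.11 log units; within the scatter), and its furthest is a 14-fold lower number from compound 1 to compound 3 (1.15 log units; beyond the scatter).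

Compound 4 `CN1CCC(C(=O)N2Cc3c(NC(=O)c4ccco4)n[nH]c3C2(C)C)CC1` carries furan-2-yl in place of 3,4-difluorophenyl on a carbonyl carbon.

Among the compounds with values here, no compound with furan-2-yl has been measured yet, and the available steps only bracket the change. Replacing cyclopropyl with a difluorophenyl group gave large steps, an 11-fold lower number from compound 1 to compound 2 (1.04 log units; beyond the scatter) and a 14-fold lower number from compound 1 to compound 3 (1.15 log units; beyond the scatter). Exchanging one difluorophenyl group for the other gave only a 1.3-fold lower number from compound 2 to compound 3 (0.11 log units; within the scatter). Furan-2-yl keeps an aromatic ring on the carbonyl carbon, but that ring is a five-membered one. A moderate move towards a higher number in this assay therefore seems likely, falling short of the value of compound 1, 1420 nM.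

The expected step is a 3.0-fold higher number from compound 3 to compound 4 (0.48 log units; beyond the scatter).

The estimated value for compound 4 is 300 nM, with an expected range of 110 nM to 800 nM.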

Compound 4, half-maximal inhibitory concentration in the A2780 assay: > 5000 nM
Compound 4: only a limit was reported (the forecaster's own chance of this, stated with the estimate: 1%); middle value at least 16-fold (1.22 log units) away from the limit.
By their numbers in the A2780 assay, from the lowest: compounds 3 and 2 (each within the scatter of the next); then compound 1. At a limit, above all of these: compound 4.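

In the A2780 assay compound 4 gives > 5000 nM, which is a limit of the assay and not a number: the limit of > 5000 nM in the A2780 assay, at which 1 of the 4 values shown sits.

Furan-2-yl on this carbonyl carbon does not keep the low numbers of the difluorophenyl compounds in the A2780 assay (an at least 50-fold higher number from compound 3 to compound 4 (1.69 log units; beyond the scatter); an at least 38-fold higher number from compound 2 to compound 4 (1.58 log units; beyond the scatter)), and it also falls behind cyclopropyl (an at least 3.5-fold higher number from compound 1 to compound 4 (0.54 log units; beyond the scatter)). An aromatic ring on this carbonyl carbon is thus not enough by itself, which compound 1 alone could not show: among the compounds shown, only the six-membered difluorophenyl rings of compound 2 and compound 3 go with the low numbers.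

In a physicochemical assay for solubility, at pH 7 (on this read-out lower numbers stand for lower solubility and higher numbers for higher solubility), compound 3 gives > 225000 nM, which is a limit of the assay and not a number. In the physicochemical assay compound 4 gives > 225000 nM, which is also a limit of the assay and not a number. In the physicochemical assay the step from compound 3 to compound 4 cannot be read, and both values are limits: the limit of > 225000 nM in the physicochemical assay, at which 2 of the 2 values shown sit.

On these data alone, whether the loss follows the ring size, the ring oxygen or the missing fluorines stays open, and unsubstituted phenyl or thiophen-2-yl at this place would help to separate these.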